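Swapping a thiazole amide for an anilide: lipophilicity outlook

A few compounds are considered here, and "the series" means these few. Any claim that something is new, unique, unknown or untested is made for them only; others in the source may bear on it.

Measured compounds and their values:
compound 1 `NCc1csc(NC(=O)c2ccc(Cl)cc2)n1` gives 1.6
compound 2 `NCc1csc(NC(=O)c2ccn[nH]2)n1` gives 0.1
compound 3 `Cc1csc(NC(=O)c2cc(C(C)(C)C)nn2Cc2ccccc2)n1` gives 4.7

These numbers come from a physicochemical assay for lipophilicity, read by HPLC, at pH 7.4; a higher number here means a more lipophilic compound, a lower number a more polar compound. Compound 3 stands highest of the three. Compound 1 is its nearest neighbour, with a number lower by a gap beyond the scatter, and compound 2 lies furthest away, lower still, again beyond the scatter. Compound 4 `CC(C)(C)c1cc(C(=O)Nc2ccccc2)n(Cc2ccccc2)n1` has not yet been measured in this assay. It differs from compound 3 in one place only: phenyl in place of 4-methyl-1,3-thiazol-2-yl on an amide-type nitrogen. The group that leaves is counted with two hydrogen-bond acceptors, while the phenyl that enters is counted with none. For the measured compounds named here, no pair of measured compounds differs in just this way, so there is no measured step to lean on; the expectation rests on compound 3 alone and on the nature of the change. An upward step is expected, of modest size but likely beyond the scatter, in this assay. Compound 4 is therefore expected to reach about 5.3, with a range from 4.8 to 5.8. The step of a number 0.60 log units higher from compound 3 to compound 4 (beyond the scatter) is the change this estimate implies.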

Compound 4, distribution coefficient: 4.7
Compound 4: middle estimate off by 0.60 log units, on the high side; measured number below the stated range.
By their numbers in this assay, from the lowest: compound 2; then compound 1; then compounds 3 and 4 (each within the scatter of the next).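

On an amide-type nitrogen, with everything else in the molecule unchanged, putting phenyl in place of 4-methyl-1,3-thiazol-2-yl gives, in this assay, no change at the digits printed from compound 3 to compound 4 (within the scatter). This is the first single change that can be read directly among these compounds, and it shows that the two ring groups, each with the same count of heavy atoms, cannot be told apart by this number, even though the group that leaves is counted with two hydrogen-bond acceptors and the phenyl that enters with none. At this position, then, the difference in acceptor count comes with no readable shift, and no measurement at hand accounts for the match.

This single step leaves open how other groups on the same nitrogen would read, for instance a phenyl carrying a carboxylic acid or a hydroxyl group, or a longer alkyl chain in place of the ring. It also leaves open whether the same swap would give the same reading on a different core, such as that of compound 1, which carries a different group on the amide carbonyl.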